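Halogen on the shared core: compound 1 to compound 3

The source may report more compounds than this note shows. Statements on the series, on what has been measured and on what is new or still open speak of the compounds shown alone.

Compound 1 `c1cncc(-c2nc3ccccc3n2C2CC2)c1` sits at the limit of an assay on V79 cells for inhibition of cytochrome P450 11B1, mitochondrial (Homo sapiens), read by HTRF, with a stated time of 1 h; a higher number here means a weaker inhibitor, a lower number a stronger inhibitor: in this assay compound 1 reaches only > 8330 nM, which is a limit and not a number (the limit of > 8330 nM in this assay, at which 1 of the 2 values shown sits). Compound 2 `Fc1ccc2c(c1)nc(-c1cccnc1)n2C1CC1` gives in this assay 3980 nM. Within the data shown here, the only measured step is an at least 2.0-fold lower number from compound 1 to compound 2 (0.32 log units; beyond the scatter). Compound 3 `Clc1ccc2nc(-c3cccnc3)n(C3CC3)c2c1` carries chloro in place of hydrogen on an aromatic carbon. For compound 3 a step of an at least 2.7-fold lower number from compound 1 to compound 3 (0.44 log units; beyond the scatter) is expected, a lowering beyond the scatter, because an at least 2.0-fold lower number from compound 1 to compound 2 (0.32 log units; beyond the scatter) already went that way with a halogen at the same place. Compound 3 is therefore estimated at 3000 nM, between 1000 nM and 9000 nM.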

Compound 3, half-maximal inhibitory concentration: 477 nM
The estimate for compound 3 lay 6.3-fold (0.80 log units) above the measured number, outside the stated range (below it).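

In this assay, a single chlorine on this aromatic carbon of the shared core gives an at least 17-fold lower number from compound 1 to compound 3 (1.24 log units; beyond the scatter), a large step from one heavy atom. This is the first large lowering shown in the series, and compound 3 now gives a measured anchor at this position. The true size of the step stays open because compound 1 stands at a limit: the limit of > 8330 nM in this assay, at which 1 of the 3 values shown sits.

Open, as far as these compounds go, is whether bromo, methoxy or an amine on this same carbon would lower the number as well, or further.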